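The compounds below may be only part of what the source reports. "The series", "measured", "known", "first", "only" and "open" are said of these compounds alone.

Going by the values given here, the three compounds measured so far share one core, seen in compound 1 `O=C1C=C(NCc2ccccc2)C(=O)c2c1nc1n2[C@H]2OC[C@@H](O)[C@H]2OC1`, compound 2 `O=C1C(NC2CCCC2)=CC(=O)c2c1nc1n2[C@H]2OC[C@@H](O)[C@H]2OC1` and compound 3 `O=C1C=C(Nc2ccc(Br)cc2)C(=O)c2c1nc1n2[C@H]2OC[C@@H](O)[C@H]2OC1`. In a functional assay on MGC-803 cells (Homo sapiens) for inhibition, read by sulforhodamine B assay (a lower number here means a stronger inhibitor, a higher number a weaker inhibitor), compound 1 gives 2670 nM and compound 3 gives 1010 nM; the step of a 2.6-fold lower number from compound 1 to compound 3 (0.42 log units; beyond the scatter) is modest but beyond the scatter. Compound 2 sits at the limit of > 16000 nM in this assay, at which 1 of the 3 values shown sits, a limit of the assay and not a number, so in this assay compound 2 gives > 16000 nM. Compound 4 `O=C1C(Nc2cccc(F)c2)=CC(=O)c2c1nc1n2[C@H]2OC[C@@H](O)[C@H]2OC1` differs from compound 2 by 3-fluorophenyl in place of cyclopentyl on an amine nitrogen. Among the compounds with values here, no measured step replaces cyclopentyl with an aryl group; the nearest comparison, benzyl to 4-bromophenyl, favoured the aryl. A large gain from the limit is therefore expected, an at least 6.4-fold lower number from compound 2 to compound 4 (0.80 log units; beyond the scatter). The estimate for compound 4 is 2500 nM, within 800 nM to 8000 nM.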

Compound 4, half-maximal inhibitory concentration: 1470 nM
For compound 4 the middle estimate is 1.7-fold (0.23 log units) above the measured one; the range from low to high includes it.
By their numbers in this assay, from the lowest: compounds 3, 4 and 1 (each within the scatter of the next, the first and the last beyond it). At a limit, above all of these: compound 2.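

Replacing cyclopentyl with 3-fluorophenyl on this amine nitrogen gives an at least 10-fold lower number from compound 2 to compound 4 (1.03 log units; beyond the scatter) in this assay. This is the first step shown from a non-aromatic ring to an aromatic one at such a nitrogen, and it is large. Its size is only a bound, because compound 2 stands at a limit of the assay and not at a number: the limit of > 16000 nM in this assay, at which 1 of the 4 values shown sits. Going by these compounds, what a plain phenyl or a cyclohexyl on this amine nitrogen would give stays open, and with it whether the gain goes with the aromatic ring or with the fluorine.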